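Capping the Amine of Compound 3 with Methylsulfonyl

A few compounds are considered here, and "the series" means these few. Any claim that something is new, unique, unknown or untested is made for them only; others in the source may bear on it.

Three ureas on one shared core were compared in an assay on isolated protein for inhibition of STE20-like serine/threonine-protein kinase (Homo sapiens), read by thermal shift assay, tested at 10 uM; a higher number here means that the compound stabilises the target more against heat, a lower number that the compound stabilises the target less. Compound 1 `CC(C)(C)c1cc(NC(=O)Nc2ccc(Cl)cc2)n(-c2ccc(OC(F)(F)F)cc2)n1` gives 0.2 degrees C; compound 2 `CC(C)(C)c1cc(NC(=O)Nc2ccc(Cl)cc2)n(-c2ccc(S(C)(=O)=O)cc2)n1` gives 5.2 degrees C; compound 3 `CC(C)(C)c1cc(NC(=O)Nc2ccc(Cl)cc2)n(-c2ccc(N)cc2)n1` gives 5.6 degrees C, the highest of the three numbers, though the step of a number 0.40 degrees C higher from compound 2 to compound 3 (within the scatter) lies within the scatter. Compound 4 `CC(C)(C)c1cc(NC(=O)Nc2ccc(Cl)cc2)n(-c2ccc(NS(C)(=O)=O)cc2)n1` differs from compound 3 by methylsulfonyl in place of hydrogen on a nitrogen on an aromatic ring. Going by the values given here, two measured steps bear on this: a number 5.0 degrees C higher from compound 1 to compound 2 (beyond the scatter) and a number 5.4 degrees C higher from compound 1 to compound 3 (beyond the scatter), both large, while the step of a number 0.40 degrees C higher from compound 2 to compound 3 (within the scatter) shows the methylsulfonyl and amino variants close together. The new group joins the nitrogen of compound 3 with the methylsulfonyl of compound 2. For compound 4 no step beyond the scatter is expected, a number 0.60 degrees C lower from compound 3 to compound 4 (within the scatter). Compound 4 is therefore estimated at 5 degrees C, with a range of 3 degrees C to 7 degrees C.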

Compound 4, shift of the target's melting temperature: 7.3 degrees C
Compound 4: the middle estimate sits 2.3 degrees C below what was measured; the measured number lies above the stated range.
By their numbers in this assay, from the lowest: compound 1; then compounds 2 and 3 (each within the scatter of the next); then compound 4.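

On the aromatic carbon where compounds 2 and 3 lie within the scatter of each other in this assay, methanesulfonamido goes beyond both: a number 1.7 degrees C higher from compound 3 to compound 4 (beyond the scatter) and a number 2.1 degrees C higher from compound 2 to compound 4 (beyond the scatter). Adding methylsulfonyl to the nitrogen of the amino group therefore raises the number rather than leaving it unchanged, which the earlier compounds could not show. Against trifluoromethoxy, the step widens to a number 7.1 degrees C higher from compound 1 to compound 4 (beyond the scatter).

As far as these compounds go, whether an acetamido group, an ethanesulfonamido group or an N-methyl methanesulfonamido group would hold or extend this gain remains open. Nothing available here explains the rise.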